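The source may hold more compounds than are shown below. What is called first, only, known or untested is meant among the compounds shown, and "the series" means these compounds.

Measured in an ADME assay on the whole organism (plasma) for pharmacokinetics, with Rattus norvegicus as the target, at a dose of 5 mg/kg by the oral route; a lower number here means less compound in the circulation, a higher number more compound in the circulation at the dose given:
- compound 1 `CCC(CC)[C@@H]1C(=O)N[C@H](C2Cc3ccccc3C2)C(=O)N1[C@@H](C(=O)N1CCOCC1)c1ccc(C)nc1`: 1380 ng.h/mL
- compound 2 `Cc1ccc([C@H](C(=O)N(C)C)N2C(=O)[C@@H](C3Cc4ccccc4C3)NC(=O)[C@H]2CC(C)C)cn1`: 2680 ng.h/mL
- compound 3 `CCC(CC)[C@@H]1C(=O)N[C@H](C2Cc3ccccc3C2)C(=O)N1[C@@H](C(=O)N(C)C)c1ccc(C)nc1`: 1810 ng.h/mL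

Compound 3, at 1810 ng.h/mL, falls inside the span of these numbers, and both of its measured steps stay within the scatter. Compound 4 `Cc1ccc([C@H](C(=O)N(C)C)N2C(=O)[C@@H](C3Cc4ccccc4C3)NC(=O)[C@H]2CC(C)(C)C)cn1` is still to be measured in this assay. It carries neopentyl in place of pentan-3-yl on a saturated ring carbon.

Within the data shown here, two measured steps bear on this. The closer guide changes the same ring carbon, with pentan-3-yl in place of isobutyl: a 1.5-fold lower number from compound 2 to compound 3 (0.17 log units; within the scatter). The other, dimethylamino in place of morpholin-4-yl on a carbonyl carbon, is a change elsewhere: a 1.3-fold higher number from compound 1 to compound 3 (0.12 log units; within the scatter). Among the measured compounds shown here, no neopentyl compound has been measured yet, so the direction remains open. Neither step leaves the scatter, so no change beyond it is expected here. The expected result is a 1.2-fold higher number from compound 3 to compound 4 (0.06 log units; within the scatter). For compound 4 the estimated value is 2100 ng.h/mL, with an expected range from 1000 ng.h/mL to 4500 ng.h/mL.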

Compound 4, area under the concentration-time curve: 618 ng.h/mL
Beside the measured number, compound 4's estimate is 3.4-fold (0.53 log units) above it; measured number below the stated range.
By their numbers in this assay, from the lowest: compound 4; then compounds 1, 3 and 2 (each within the scatter of the next).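

In this assay, among these compounds, this saturated ring carbon proves sensitive to how the same atoms are joined: neopentyl in place of pentan-3-yl gives (a 2.9-fold lower number from compound 3 to compound 4 (0.47 log units; beyond the scatter)), the first step at this position to pass the scatter. Methyl in place of hydrogen on the saturated chain carbon bound to three saturated chain carbons, which turns the isobutyl of compound 2 into neopentyl, gives (a 4.3-fold lower number from compound 2 to compound 4 (0.64 log units; beyond the scatter)), whereas isobutyl and pentan-3-yl remain within the scatter of each other. No measurement at hand accounts for the lower number with neopentyl.

On these data alone, whether that lower number persists with morpholin-4-yl on the carbonyl carbon remains open, as does how cyclopropylmethyl or a hydroxyl-bearing chain on this ring carbon would read in this assay here. Only oral exposure is shown, so uptake and clearance are not separated.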